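Swapping trifluoromethyl for methoxy on the benzyl ring

The compounds below may be only part of what the source reports. "The series", "measured", "known", "first", "only" and "open" are said of these compounds alone.

Compound 1 `O=S(=O)(NCCNCc1ccc(-c2ccccc2)cc1)c1cc(C(F)(F)F)cc(C(F)(F)F)c1`: 2400 nM
Compound 2 `O=S(=O)(NCCCNCc1ccc(Cl)c(C(F)(F)F)c1)c1cc(C(F)(F)F)cc(C(F)(F)F)c1`: 9100 nM
Compound 3 `O=S(=O)(NCCCNCc1ccc(C(F)(F)F)cc1)c1cc(C(F)(F)F)cc(C(F)(F)F)c1`: 2000 nM

All three share a bis(trifluoromethyl)benzenesulfonamide core joined through a short diamine chain to a benzyl group, and all were tested in a functional assay on Capan-2 cells (Homo sapiens) for inhibition, read by MTT assay, with a stated time of 72 h; on this read-out lower numbers stand for stronger inhibition of growth and higher numbers for weaker inhibition of growth. Compound 3 gives the lowest number of the three, 2000 nM, although compound 1 with 2400 nM sits within the scatter of it, so the two cannot be ordered. Among the measured compounds shown here, compound 2 stands apart at 9100 nM; the only single-point step, a 4.6-fold lower number from compound 2 to compound 3 (0.66 log units; beyond the scatter), shows that a change on this benzyl ring can move the read-out.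

Compound 4 `COc1ccc(CNCCCNS(=O)(=O)c2cc(C(F)(F)F)cc(C(F)(F)F)c2)cc1` differs from compound 3 by methoxy in place of trifluoromethyl on an aromatic carbon. For the measured compounds named here, no measured pair tests this exact exchange, so the step is uncertain. The result is expected to stay close to compound 3, with the step of a 1.5-fold higher number from compound 3 to compound 4 (0.18 log units; within the scatter) judged roughly within the scatter, leaning weaker. Compound 4 is therefore estimated at 3000 nM, in the range 1000 nM to 9000 nM.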

Compound 4, concentration for 50% growth inhibition: 2400 nM
Beside the measured number, compound 4's estimate is 1.3-fold (0.10 log units) above it, within the range that was stated.
By their numbers in this assay, from the lowest: compounds 3, 1 and 4 (each within the scatter of the next); then compound 2.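

Exchanging trifluoromethyl for methoxy on this aromatic carbon gives a 1.2-fold higher number from compound 3 to compound 4 (0.08 log units; within the scatter) in this assay, so this read-out does not separate the two groups, even though they differ in their atoms and only methoxy counts as a hydrogen-bond acceptor. The 4-methoxyphenyl group also stands apart from the 4-chloro-3-(trifluoromethyl)phenyl group, with a 3.8-fold lower number from compound 2 to compound 4 (0.58 log units; beyond the scatter), so the lower number seen earlier with compound 3 does not require trifluoromethyl at this place. Nothing shown here explains why these two groups read alike.

As far as these compounds go, whether an amine or a carboxylic acid on this same aromatic carbon would also leave the number in this range stays open. So does whether the exchange from trifluoromethyl to methoxy would read the same on a longer chain.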